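The compounds below may be only part of what the source reports. "The series", "measured", "known", "first", "only" and "open" are said of these compounds alone.

Working notes on the series. Going by the values given here, compound 1 `CCc1ccc(NC2=CC(=O)c3c(nc4n3[C@H]3OC[C@@H](O)[C@H]3OC4)C2=O)cc1` is the one compound here with a numerical result: in a functional assay on MCF7 cells (Homo sapiens) for inhibition, read by sulforhodamine B assay (a lower number here means a stronger inhibitor, a higher number a weaker inhibitor), compound 1 gives 8990 nM, which places it at the weak end of the scale. Compound 2 `CCOc1ccccc1NC1=CC(=O)c2nc3n(c2C1=O)[C@H]1OC[C@@H](O)[C@H]1OC3` carries a limit rather than a number: in this assay compound 2 gives > 4000 nM, a limit of the assay and not a measured value. That is the limit of > 4000 nM in this assay, at which 1 of the 2 values shown sits.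

Compound 3 `COc1cccc(NC2=CC(=O)c3c(nc4n3[C@H]3OC[C@@H](O)[C@H]3OC4)C2=O)c1` is not yet measured. It differs from compound 1 in a single place: 3-methoxyphenyl in place of 4-ethylphenyl on an amine nitrogen. The shared core and the amine nitrogen are kept; only the aryl group on that nitrogen is exchanged.

Among the compounds with values here, no step between two measured compounds is available, so nothing in the data fixes the size or direction of this exchange. With compound 1 already weak in this assay at 8990 nM, the expected step is a 1.0-fold higher number from compound 1 to compound 3 (0.00 log units; within the scatter), that is, none beyond the scatter, in no particular direction. The estimate for compound 3 in this assay is 9000 nM, expected to fall between 3000 nM and 30000 nM. A limit report for compound 3 is also possible.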

Compound 3, half-maximal inhibitory concentration: 3830 nM
Estimate against measurement, compound 3: 2.3-fold (0.37 log units) above; the range from low to high includes it.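

In this assay, going by these compounds alone, the exchange of 4-ethylphenyl for 3-methoxyphenyl on the amine nitrogen gives a 2.3-fold lower number from compound 1 to compound 3 (0.37 log units; beyond the scatter), the first step that can be read, and it shows that the number responds to the aryl group at this place, if only modestly. The two groups have the same count of heavy atoms, and the entering group differs in having an oxygen and a hydrogen-bond acceptor, but the substituent and its place on the ring change together, so this one step cannot assign the change to either. Compound 2 carries a limit of the assay and not a number, so steps to it cannot be read: the limit of > 4000 nM in this assay, at which 1 of the 3 values shown sits.

Still open, as far as these compounds go, is whether the step follows the substituent or its place on the ring, which 3-ethylphenyl and 4-methoxyphenyl on the same nitrogen would separate. The compounds shown also leave open how the series responds to an aryl group carrying a carboxylic acid or an amine, or to a pyridine ring in place of the benzene ring.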